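Moving from a fluorobenzyl to a methoxybenzyl substituent

This account rests on a few compounds, and the source may have more. Where it says the series, first, only, none or still open, it means among the compounds named here.

Compound 3 `CCOC(=O)c1ccc(-c2nn(Cc3ccc(F)cc3)c3ccccc23)cc1` gives 190 nM in a functional assay on cells (Platelet, Homo sapiens) for inhibition (a higher number here means a weaker inhibitor, a lower number a stronger inhibitor), the second highest of the three numbers shown. Compound 2 `CCOC(=O)c1ccc(-c2nn(Cc3cccc(F)c3)c3ccccc23)cc1` gives 270 nM and compound 1 `CCOC(=O)c1ccc(-c2nn(Cc3ccc(Cl)cc3)c3ccccc23)cc1` gives 120 nM; both the step of a 1.4-fold lower number from compound 2 to compound 3 (0.15 log units; within the scatter) and the step of a 1.6-fold higher number from compound 1 to compound 3 (0.20 log units; within the scatter) are within the scatter. Compound 4 `CCOC(=O)c1ccc(-c2nn(Cc3ccccc3OC)c3ccccc23)cc1` carries 2-methoxyphenyl in place of 4-fluorophenyl on a saturated chain carbon bound to an aromatic nitrogen. For the measured compounds named here, no measured step involves a methoxy group. The comparisons that bear on it are a 2.3-fold higher number from compound 1 to compound 2 (0.35 log units; beyond the scatter), which combines a halogen swap with a change of ring position, and a 1.4-fold lower number from compound 2 to compound 3 (0.15 log units; within the scatter), a change of position alone. These suggest that altering the substituent on this ring shifts the number only slightly, so compound 4 is expected to show a 1.3-fold higher number from compound 3 to compound 4 (0.12 log units; within the scatter), a step within the scatter. The estimate for compound 4 is 250 nM, with a range from 100 nM to 700 nM.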

Compound 4, half-maximal inhibitory concentration: 470 nM
The estimate for compound 4 lay 1.9-fold (0.27 log units) below the measured number; measured number inside the range.
By their numbers in this assay, from the lowest: compounds 1, 3, 2 and 4 (each within the scatter of the next, the first and the last beyond it).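

Substituents on this benzyl ring do not all sit within the scatter of one another: in this assay the 2-methoxyphenyl group gives steps beyond it from the halogen compounds (a 2.5-fold higher number from compound 3 to compound 4 (0.39 log units; beyond the scatter)) and (a 3.9-fold higher number from compound 1 to compound 4 (0.59 log units; beyond the scatter)). The step from the 3-fluorophenyl compound (a 1.7-fold higher number from compound 2 to compound 4 (0.24 log units; within the scatter)) stays within the scatter, so compound 4 cannot be separated from compound 2. Nothing available explains these shifts. As far as these compounds go, it remains open whether they follow the methoxy group itself or its place on the ring, and how an amine or a hydroxyl group on this ring would read.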